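Methoxy for cyclopropyl: an expected loss of potency

This account rests on a few compounds, and the source may have more. Where it says the series, first, only, none or still open, it means among the compounds named here.

Compounds measured so far:
compound 1 `Cc1cc(C(=O)O)c(C)n1-c1cccc(F)c1` — 1500 nM
compound 2 `Cc1cccc(-n2c(C)cc(C(=O)O)c2C)c1` — 1500 nM... (see below)

Compound 1 `Cc1cc(C(=O)O)c(C)n1-c1cccc(F)c1` gives 1500 nM in an assay on cells for inhibition of Palmitoleoyl-protein carboxylesterase NOTUM variant C330S (Homo sapiens), read by fluorescence, with a stated time of 40 min; on this read-out lower numbers stand for stronger inhibition and higher numbers for weaker inhibition. Compound 2 `Cc1cccc(-n2c(C)cc(C(=O)O)c2C)c1` gives 1500 nM in this assay. Compound 3 `Cc1cc(C(=O)O)c(C)n1-c1cccc(C2CC2)c1` gives 580 nM in this assay and stands lowest of the three, with both compound 1 and compound 2 beyond the scatter above it.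

Compound 4 `COc1cccc(-n2c(C)cc(C(=O)O)c2C)c1` differs from compound 3 by methoxy in place of cyclopropyl on an aromatic carbon. Going by the values given here, three measured steps bear on it. The step of no change at the digits printed from compound 1 to compound 2 (within the scatter) shows that fluoro and methyl on that aromatic carbon give the same number. The steps of a 2.6-fold lower number from compound 1 to compound 3 (0.41 log units; beyond the scatter) and a 2.6-fold lower number from compound 2 to compound 3 (0.41 log units; beyond the scatter) show that cyclopropyl is the one group among these that lowers the number, and only modestly. Methoxy is a third small group at the same aromatic carbon, and nothing measured sets it apart from fluoro or methyl, so the cyclopropyl advantage is expected to be lost. In this assay compound 4 is therefore expected to move by a 2.4-fold higher number from compound 3 to compound 4 (0.38 log units; beyond the scatter), back toward the level of compound 1 and compound 2. The estimated value for compound 4 is 1400 nM, with a range from 550 nM to 3600 nM.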

Compound 4, half-maximal inhibitory concentration: 1500 nM
Compound 4: middle estimate off by 1.1-fold (0.03 log units), on the low side, within the range that was stated.
By their numbers in this assay, from the lowest: compound 3; then compounds 1, 2 and 4 (each within the scatter of the next).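

In this assay, methoxy in place of cyclopropyl on this aromatic carbon gives a 2.6-fold higher number from compound 3 to compound 4 (0.41 log units; beyond the scatter) and so gives up the modest advantage seen with cyclopropyl. Methoxy also stands level with the two other groups at this carbon, with no change at the digits printed from compound 2 to compound 4 (within the scatter) on the change from methyl and no change at the digits printed from compound 1 to compound 4 (within the scatter) on the change from fluoro, so among the four groups shown only cyclopropyl stands apart, and the hydrogen-bond acceptor that methoxy brings in gives no lower number than fluoro or methyl. Nothing available here accounts for why cyclopropyl alone differs from the other three.

The compounds shown leave open whether it is the three-membered ring itself that matters, since an isopropyl or ethyl group on the same carbon would separate the ring from the carbon count, and whether a cyclobutyl or tert-butyl group would lower the number further. They also leave open how an amine or a nitrile at this carbon would compare, and whether the gain from cyclopropyl would hold at any other carbon of the six-membered aromatic ring.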